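Ester-to-amide change on the core of compound 3

The source may report more compounds than this note shows. Statements on the series, on what has been measured and on what is new or still open speak of the compounds shown alone.

Three compounds have numbers in an assay on isolated protein for inhibition of Gonadotropin-releasing hormone receptor (Homo sapiens); a higher number here means a weaker inhibitor, a lower number a stronger inhibitor. Compound 1 `Cc1cccc(CSc2nc3cc(NC(=O)C4CC4)ccc3n2C(C)C)c1` gives 6500 nM. Compound 2 `COc1ccc([N+](=O)[O-])cc1CSc1nc2cc(NC(=O)NC(C)(C)C)ccc2n1Cc1cccnc1` gives 33 nM. Compound 3 `CCCn1c(SCc2cc([N+](=O)[O-])ccc2OC)nc2cc(NC(=O)NC(C)(C)C)cc(C(=O)OC)c21` gives 37 nM. Compound 3 stands second highest of the three; its nearest neighbour is compound 2, whose number lies within the scatter of that of compound 3, so no order between compounds 2 and 3 can be read. Its furthest neighbour is compound 1, whose number is far higher and well beyond the scatter, so compound 1 is the clearly weaker inhibitor of the three.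

Compound 4 `CCCn1c(SCc2cc([N+](=O)[O-])ccc2OC)nc2cc(NC(=O)NC(C)(C)C)cc(C(=O)NCc3ccncc3)c21` is not yet measured. It differs from compound 3 by ((pyridin-4-yl)methyl)amino in place of methoxy on a carbonyl carbon. Within the data shown here, no pair of measured compounds shows this change, so its effect is unknown from the series. The expected outcome is a step no larger than the scatter, leaning slightly toward a lower number, written as a 1.5-fold lower number from compound 3 to compound 4 (0.17 log units; within the scatter). Compound 4 is thus estimated at 25 nM, within 8 nM to 80 nM.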

Compound 4, half-maximal inhibitory concentration: 61 nM
Beside the measured number, compound 4's estimate is 2.4-fold (0.39 log units) below it, and the stated range covers the measured number.
By their numbers in this assay, from the lowest: compounds 2, 3 and 4 (each within the scatter of the next); then compound 1.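

In this assay, among these compounds, a 1.6-fold higher number from compound 3 to compound 4 (0.22 log units; within the scatter) gives the first reading at this position, and it lies within the scatter, so no order can be read between the two compounds. On this carbonyl carbon, whose other neighbour is an aromatic carbon, a small methoxy and the much larger ((pyridin-4-yl)methyl)amino, which brings a six-membered aromatic ring and a hydrogen-bond donor, therefore give numbers that cannot be told apart. No supporting data bear on this result.

This single step changes the ester to an amide and adds the ring at once, so the contribution of each remains unresolved. Still open, on these data alone, is whether the same holds for a carboxylic acid, a plain methylamino group or a benzylamino group at this carbonyl carbon.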